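Methyl to methoxy on the benzyl ring of compound 3

This account rests on a few compounds, and the source may have more. Where it says the series, first, only, none or still open, it means among the compounds named here.

Measured so far:
compound 1 `CN1CCN(CC(=O)Nc2ccc(-c3nc(-c4ccccc4)c(-c4ccccc4)n3C)cc2)CC1` — 27.4%
compound 2 `CN(C)/C=C/N1CCN(CC(=O)Nc2ccc(-c3nc(-c4ccccc4)c(-c4ccccc4)n3C)cc2)CC1` — 8%
compound 3 `Cc1ccc(CN2CCN(CC(=O)Nc3ccc(-c4nc(-c5ccccc5)c(-c5ccccc5)n4C)cc3)CC2)cc1` — 26.4%

In a functional assay on HT-29 cells (Homo sapiens) for cytotoxicity, read by MTT assay, with a stated time of 24 h, tested at 1.6 ug/mL (a lower number here means a weaker effect, a higher number a stronger effect of the compound at the concentration tested), compound 3 gives 26.4%, the second highest of the three numbers. Its nearest neighbour is compound 1 at 27.4%; the step of a number 1 percentage points lower from compound 1 to compound 3 (within the scatter) lies within the scatter, so the two cannot be ordered. The step of a number 18.4 percentage points higher from compound 2 to compound 3 (beyond the scatter) is beyond the scatter, and a number 19.4 percentage points lower from compound 1 to compound 2 (beyond the scatter) likewise separates compound 2 from the rest.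

Compound 4 `COc1ccc(CN2CCN(CC(=O)Nc3ccc(-c4nc(-c5ccccc5)c(-c5ccccc5)n4C)cc3)CC2)cc1` differs from compound 3 at one point: methoxy in place of methyl on an aromatic carbon. The change sits on an aromatic carbon of a six-membered aromatic ring of carbon only. For the measured compounds named here, no measured step touches this ring; the only step on the same amine nitrogen, a number 1 percentage points lower from compound 1 to compound 3 (within the scatter), is within the scatter, which says nothing about a substituent on the benzyl ring itself. With no bearing data, no step beyond the scatter is expected, and compound 4 is estimated at 26% (range 12% to 40%), that is an expected step of a number 0.4 percentage points lower from compound 3 to compound 4 (within the scatter).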

Compound 4, a percentage reported as activity, at one concentration (the size of the read-out at that concentration, not a potency): 10.1%
The estimate for compound 4 lay 15.9 percentage points above the measured number; the whole stated range lies above it.
By their numbers in this assay, from the lowest: compounds 2 and 4 (each within the scatter of the next); then compounds 3 and 1 (each within the scatter of the next).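

Notes on the benzyl ring: in this assay this ring position responds to a small change, since methoxy in place of methyl, para to a large group, gives a number 16.3 percentage points lower from compound 3 to compound 4 (beyond the scatter) and is the first step beyond the scatter on this ring. The 4-methoxybenzyl group thus does not keep the level of the methyl on the amine nitrogen, with a number 17.3 percentage points lower from compound 1 to compound 4 (beyond the scatter), and a number 2.1 percentage points higher from compound 2 to compound 4 (within the scatter) places compound 4 within the scatter of compound 2, unlike compound 3. No available evidence explains this step.

On these data alone, whether a 4-ethylbenzyl, 4-chlorobenzyl or 4-hydroxybenzyl group would read like compound 3 or compound 4 remains open. So does the effect of methoxy on another carbon of this ring, and a single concentration in one cell line cannot show whether the step holds at other concentrations.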